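The source may hold more compounds than are shown below. What is called first, only, known or untested is meant among the compounds shown, and "the series" means these compounds.

Measured so far:
compound 1 `Cc1nc(C(F)(F)F)ccc1C(=O)Nc1ccc(Cl)c(-c2cn3ccsc3n2)c1` — 200 nM
compound 2 `Cc1nc(C(F)(F)F)ccc1C(=O)Nc1ccc(Cl)c(-c2ncccn2)c1` — 8000 nM

Among the measured compounds shown here, in an assay on C3H 10T1/2 cells for inhibition of Sonic hedgehog protein (Mus musculus), read by a luciferase reporter (a lower number here means a stronger inhibitor, a higher number a weaker inhibitor), compound 2 stands at the highest of the two numbers, with compound 1 the nearest and clearly lower; the single measured step, a 40-fold higher number from compound 1 to compound 2 (1.60 log units; beyond the scatter), is large and beyond the scatter.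

Compound 3 `Cc1nc(C(F)(F)F)ccc1C(=O)Nc1ccc(Cl)c(-c2cnccn2)c1` is to be measured next. It differs from compound 2 only in pyrazin-2-yl in place of pyrimidin-2-yl on an aromatic carbon. For the measured compounds named here, no measured step concerns an exchange of one six-membered ring for another of the same atom count; the step from compound 1 to compound 2 replaces a different kind of group altogether and cannot be carried over to this change. Nothing here argues for a move in either direction, so for compound 3 a step within the usual scatter is expected, no change at the digits printed from compound 2 to compound 3 (within the scatter). Compound 3 is accordingly estimated at 8000 nM, within a range of 3000 nM to 20000 nM in this assay.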

Compound 3, half-maximal inhibitory concentration: 1700 nM
Beside the measured number, compound 3's estimate is 4.7-fold (0.67 log units) above it, and the stated range ends above it.
By their numbers in this assay, from the lowest: compound 1; then compound 3; then compound 2.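

In this assay, this position responds to how the ring is built even when the counts stay the same: pyrazin-2-yl and pyrimidin-2-yl have the same heavy atoms and hydrogen-bond acceptor count, yet the exchange gives a 4.7-fold lower number from compound 2 to compound 3 (0.67 log units; beyond the scatter). The loss on leaving the two-ring group of compound 1 is therefore not set by the six-membered ring alone, although an 8.5-fold higher number from compound 1 to compound 3 (0.93 log units; beyond the scatter) leaves compound 1 the lowest of the three. Nothing measured here accounts for the difference between the two rings.

Only two arrangements of the ring nitrogens are shown, so no rule for their placing can be drawn. Open too, as far as these compounds go, is where a phenyl or pyridin-2-yl ring would fall at this place on the shared core, and whether either would reach the level of compound 1.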